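The compounds below may be only part of what the source reports. "The series", "measured", "known", "first", "only" and "open" are said of these compounds alone.

Compound 1 `O=C(Nc1cc(-c2ccccc2)nn1-c1ccccc1)c1ccccc1` is the benzamide of the shared core; in a functional assay on cells for positive allosteric modulation of metabotropic glutamate receptor 5 (Rattus norvegicus), read by calcium flux (a higher number here means that more compound is needed for the effect, a lower number that less compound is needed), compound 1 gives 203 nM. Compound 2 `N#Cc1cccc(-n2nc(-c3ccccc3)cc2NC(=O)c2ccccc2)c1` carries a nitrile on one of the phenyl rings and in this assay compound 2 gives 117 nM. Within the data shown here, the only measured step, a 1.7-fold lower number from compound 1 to compound 2 (0.24 log units; within the scatter), leaves the two numbers within the scatter of each other, so compound 1 and compound 2 cannot be ordered on these data; compound 1 simply has the higher of the two numbers.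

Compound 3 `O=C(Nc1cc(-c2ccccc2)nn1-c1ccccc1)C1CCCC1` differs from compound 1 by cyclopentyl in place of phenyl on a carbonyl carbon. Among the measured compounds shown here, no measured step touches the carbonyl substituent: the single known step concerns a nitrile on an aromatic carbon and is itself within the scatter, so it gives no guide to the size or direction of the present change. The expectation for compound 3 must therefore rest on compound 1 alone, with a wide range. The estimate for compound 3 in this assay is 400 nM, between 120 nM and 1500 nM, which is expected to correspond to a 2.0-fold higher number from compound 1 to compound 3 (0.29 log units; within the scatter).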

Compound 3, half-maximal effective concentration: 3410 nM
For compound 3 the middle estimate is 8.5-fold (0.93 log units) below the measured one; measured number above the stated range.
By their numbers in this assay, from the lowest: compounds 2 and 1 (each within the scatter of the next); then compound 3.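

In this assay, among these compounds, the carbonyl substituent is the first place where a single change moves the number beyond the scatter: a 17-fold higher number from compound 1 to compound 3 (1.23 log units; beyond the scatter) is a large step for cyclopentyl in place of phenyl on a carbonyl carbon. The only earlier step, a 1.7-fold lower number from compound 1 to compound 2 (0.24 log units; within the scatter), concerned a nitrile on an aromatic carbon and stayed within the scatter, so the series is now shown not to be flat to single changes, and the benzoyl of compound 1 cannot be exchanged for cyclopentylcarbonyl without a much higher number. The counted hydrogen-bond donors and acceptors are the same for phenyl and cyclopentyl, and the groups differ in ring size and aromatic character together, so this one pair cannot separate the two.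

Still open, from the compounds shown here alone, is whether a cyclohexyl ring, a tert-butyl group, or a phenyl ring carrying an amine or a carboxylic acid on this carbonyl carbon would stay near compound 1 or follow compound 3, and whether the nitrile of compound 2 would make any difference with cyclopentyl in place. Nothing available on these compounds speaks to the cause of the large step.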